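The compounds below may be only part of what the source reports. "The series", "measured", "known", "first", "only" and "open" are said of these compounds alone.

Working notes on the series. Compound 1 `CC1(C)[C@H]2CC[C@]1(C)N(Cc1cn(-c3cccc(F)c3)nn1)C(=O)C2`, compound 2 `CC1(C)[C@H]2CC[C@]1(C)N(Cc1cn(-c3cccc(Cl)c3)nn1)C(=O)C2` and compound 3 `CC1(C)[C@H]2CC[C@]1(C)N(Cc1cn(-c3ccc(Br)cc3)nn1)C(=O)C2` share one core and differ only in the group on the aromatic nitrogen. In a functional assay on HepG2 cells (Homo sapiens) for inhibition, read by MTT assay, with a stated time of 24 h (a lower number here means a stronger inhibitor, a higher number a weaker inhibitor), compound 1 gives 80 nM, compound 2 gives 60 nM and compound 3 gives 110 nM. Compound 2 stands within the scatter of both neighbours: a 1.3-fold lower number from compound 1 to compound 2 (0.12 log units; within the scatter), a 1.8-fold higher number from compound 2 to compound 3 (0.26 log units; within the scatter), and a 1.4-fold higher number from compound 1 to compound 3 (0.14 log units; within the scatter). Compound 4 `COc1cccc(-n2cc(CN3C(=O)C[C@@H]4CC[C@@]3(C)C4(C)C)nn2)c1` arises from compound 2 by methoxy in place of chloro on an aromatic carbon. Going by the values given here, only the step from compound 1 to compound 2 concerns this position, and it stayed within the scatter; methoxy has no precedent here, so no step beyond the scatter is expected. Compound 4 is therefore expected to give 90 nM in this assay, between 40 nM and 220 nM. This amounts to an estimated 1.5-fold higher number from compound 2 to compound 4 (0.18 log units; within the scatter).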

Compound 4, half-maximal inhibitory concentration: 70 nM
The estimate for compound 4 lay 1.3-fold (0.11 log units) above the measured number; measured number inside the range.
By their numbers in this assay, from the lowest: compounds 2, 4, 1 and 3 (each within the scatter of the next).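

Methoxy on this aromatic carbon stays within the scatter of chloro (a 1.2-fold higher number from compound 2 to compound 4 (0.07 log units; within the scatter)) and of fluoro (a 1.1-fold lower number from compound 1 to compound 4 (0.06 log units; within the scatter)) in this assay, so a substituent with an oxygen atom now joins the two halogens without a step beyond the scatter. The 3-methoxyphenyl compound also stays within the scatter of the 4-bromophenyl compound (a 1.6-fold lower number from compound 3 to compound 4 (0.20 log units; within the scatter)). No measurement at hand bears on this result.

Still open, on these data alone, is whether an amine, a carboxylic acid or a longer chain at this position would give a step beyond the scatter.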